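Trimming the Piperazine: Expected Potency of Compound 4

The source may hold more compounds than are shown below. What is called first, only, known or untested is meant among the compounds shown, and "the series" means these compounds.

For the measured compounds named here, compound 2 `CCN1CCN(c2nc(Nc3ccc(C#N)c(C(F)(F)F)c3)nc(Oc3ccnc4ccccc34)n2)CC1` is the only compound here with an actual number in a functional assay on DU-145 cells (Homo sapiens) for cytotoxicity, read by sulforhodamine B assay, with a stated time of 48 h (on this read-out lower numbers stand for stronger inhibition of growth and higher numbers for weaker inhibition of growth), where compound 2 gives 86600 nM. Compound 1 `N#Cc1ccc(Nc2nc(Oc3ccnc4ccccc34)nc(N3CCN(c4ccc(F)cc4)CC3)n2)cc1C(F)(F)F` sits at a limit of the assay, > 100000 nM. Compound 3 `COc1ccc(CN2CCN(c3nc(Nc4ccc(C#N)c(C(F)(F)F)c4)nc(Oc4ccnc5ccccc45)n3)CC2)c(OC)c1OC` likewise sits at a limit, > 100000 nM. Compound 4 `N#Cc1ccc(Nc2nc(Oc3ccnc4ccccc34)nc(N3CCCCC3)n2)cc1C(F)(F)F` differs from compound 2 by piperidin-1-yl in place of 4-ethylpiperazin-1-yl on an aromatic carbon. Two measured steps alter the same amine ring: an at least 1.1-fold lower number from compound 1 to compound 2 (0.06 log units; that floor lies within the scatter), and an at least 1.1-fold higher number from compound 2 to compound 3 (0.06 log units; that floor lies within the scatter); both are floors lying within the scatter, and the limit of > 100000 nM in this assay, at which 2 of the 3 values shown sit, marks where those neighbours rest. Going by the values given here, no measured step therefore points to a shift beyond the scatter in this assay. Compound 4 is expected to give about 95000 nM, within 30000 nM to 200000 nM. The expected step of a 1.1-fold higher number from compound 2 to compound 4 (0.04 log units; within the scatter) is accordingly small, in either direction.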

Compound 4, concentration for 50% growth inhibition: 94900 nM
Compound 4: the middle estimate sits 1.0-fold (0.00 log units) above what was measured; the measured number falls inside the stated range.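

In this assay, this position now has a step with real numbers at both ends: a 1.1-fold higher number from compound 2 to compound 4 (0.04 log units; within the scatter). Swapping 4-ethylpiperazin-1-yl for piperidin-1-yl removes a ring nitrogen and the ethyl group, yet the read-out stays within the scatter. The values shown still crowd near the top of the scale: the limit of > 100000 nM in this assay, at which 2 of the 4 values shown sit.

As far as these compounds go, whether a morpholine ring or a simple primary amine at this position would move the number beyond the scatter remains open. So does whether any group here could bring much stronger inhibition of growth.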